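This account rests on a few compounds, and the source may have more. Where it says the series, first, only, none or still open, it means among the compounds named here.

Measured compounds, a functional assay, read by spectrophotometry, with a stated time of 20 min; on this read-out lower numbers stand for stronger inhibition and higher numbers for weaker inhibition:
compound 1 `CC(=O)c1ccc(NC(=O)CN(C(=O)c2ccccc2)S(=O)(=O)c2ccc([N+](=O)[O-])cc2)cc1`: 58000000 nM
compound 2 `CCC(C)C(C(=O)Nc1ccc(C(C)=O)cc1)N(C(=O)c1ccccc1)S(=O)(=O)c1ccc([N+](=O)[O-])cc1`: 50000000 nM
compound 3 `CC(=O)c1ccc(NC(=O)CN(C(=O)c2ccccc2)S(=O)(=O)c2ccccc2)cc1`: 32000000 nM

Compound 3 carries the lowest of the three numbers in this assay, yet the gap to compound 2 and the gap to compound 1, which is a 1.8-fold lower number from compound 1 to compound 3 (0.26 log units; within the scatter), both lie within the scatter; no order among the three can be read.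

Compound 4 `CCC(C)C(C(=O)Nc1ccc(C(C)=O)cc1)N(C(=O)c1ccccc1)S(=O)(=O)c1ccccc1` differs from compound 3 by sec-butyl in place of hydrogen on a saturated chain carbon bound to an amide-type nitrogen and a carbonyl carbon. Among the measured compounds shown here, the one measured step bearing on this change is a 1.2-fold lower number from compound 1 to compound 2 (0.06 log units; within the scatter), within the scatter. The step of a 1.8-fold lower number from compound 1 to compound 3 (0.26 log units; within the scatter) concerns the nitro and says nothing about the sec-butyl. For this assay the expected step is therefore a 1.1-fold lower number from compound 3 to compound 4 (0.06 log units; within the scatter), no shift beyond the scatter. Compound 4 is estimated at 28000000 nM, with a range of 12000000 nM to 70000000 nM.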

Compound 4, half-maximal inhibitory concentration: 8600000 nM
Estimate against measurement, compound 4: 3.3-fold (0.51 log units) above; measured number outside the range, below it.
By their numbers in this assay, from the lowest: compound 4; then compounds 3, 2 and 1 (each within the scatter of the next).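

In this assay, sec-butyl in place of hydrogen on the saturated chain carbon gives a 3.7-fold lower number from compound 3 to compound 4 (0.57 log units; beyond the scatter), so with no nitro on the core this position responds beyond the scatter. The size of this step depends on the core: the same change on two cores in this assay, a 1.2-fold lower number (0.06 log units; within the scatter) from compound 1 to compound 2 and a 3.7-fold lower number (0.57 log units; beyond the scatter) from compound 3 to compound 4, 3.2-fold (0.51 log units) apart, beyond the scatter of two such steps. Hydrogen in place of nitro with sec-butyl present gives a 5.8-fold lower number from compound 2 to compound 4 (0.76 log units; beyond the scatter), so the two changes do not act independently in these four compounds: the same change on two cores in this assay, a 1.8-fold lower number (0.26 log units; within the scatter) from compound 1 to compound 3 and a 5.8-fold lower number (0.76 log units; beyond the scatter) from compound 2 to compound 4, 3.2-fold (0.51 log units) apart, beyond the scatter of two such steps.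

Going by these compounds, it remains open whether a methyl or a longer chain on this carbon follows sec-butyl. On these data alone, it is also open whether an amine in place of nitro reads like hydrogen or like nitro.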